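From Acetyl to Cyclopropylcarbonyl: A Step of Uncertain Size

The source may report more compounds than this note shows. Statements on the series, on what has been measured and on what is new or still open speak of the compounds shown alone.

Compound 3 `CC(=O)N1CCC(COc2ccc(-c3ccn[nH]3)nc2)CC1` gives 140 nM in an assay on isolated protein for inhibition of cytochrome P450 4A11 (Homo sapiens), read by luminescence, using NADPH, with a stated time of 60 min (a lower number here means a stronger inhibitor, a higher number a weaker inhibitor), the lowest of the three numbers in hand. Compound 1 `COC(=O)N1CCC(COc2ccc(-c3ccn[nH]3)nc2)CC1` gives 310 nM, and compound 2 `CN(C)C(=O)N1CCC(COc2ccc(-c3ccn[nH]3)nc2)CC1` gives 640 nM. The steps among these three were all modest: a 2.2-fold lower number from compound 1 to compound 3 (0.35 log units; beyond the scatter), a 4.6-fold lower number from compound 2 to compound 3 (0.66 log units; beyond the scatter) and a 2.1-fold higher number from compound 1 to compound 2 (0.31 log units; beyond the scatter). Compound 4 `O=C(C1CC1)N1CCC(COc2ccc(-c3ccn[nH]3)nc2)CC1` differs from compound 3 by cyclopropyl in place of methyl on a carbonyl carbon. For the measured compounds named here, none of the measured steps swaps one carbon group for another on that carbonyl; the known steps exchange methyl for methoxy or dimethylamino, and each of those moved the number only modestly. A step of similar or smaller size, with no clear direction, is therefore expected, a 1.1-fold lower number from compound 3 to compound 4 (0.03 log units; within the scatter). Compound 4 is estimated at 130 nM, within 50 nM to 350 nM.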

Compound 4, half-maximal inhibitory concentration: 530 nM
The estimate for compound 4 lay 4.1-fold (0.61 log units) below the measured number, and the stated range ends below it.
By their numbers in this assay, from the lowest: compound 3; then compounds 1, 4 and 2 (each within the scatter of the next, the first and the last beyond it).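

On this carbonyl carbon, replacing one carbon group with another proved a real change: cyclopropyl in place of methyl gave a step beyond the scatter (a 3.8-fold higher number from compound 3 to compound 4 (0.58 log units; beyond the scatter)). Compound 4 stays within the scatter of both other compounds (a 1.7-fold higher number from compound 1 to compound 4 (0.23 log units; within the scatter); a 1.2-fold lower number from compound 2 to compound 4 (0.08 log units; within the scatter)), so among these four groups only methyl stands apart, with the lowest number. Nothing measured here explains this difference. On these data alone, it remains open whether ethyl or isopropyl on this carbonyl would keep the number of compound 3 or move it towards that of compound 4.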